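The compounds below may be only part of what the source reports. "The series", "measured", "known", "first", "only" and "open" are said of these compounds alone.

Compound 4 (`O=S(=O)(/C=C/c1ccc(F)cc1F)Cc1ccc(Nc2ncnc3cc(Cl)ccc23)cc1`) is the open case in these notes. In a functional assay on OVCAR-8 cells (Homo sapiens) (on this read-out lower numbers stand for stronger inhibition of growth and higher numbers for weaker inhibition of growth), compound 3 (`O=S(=O)(/C=C/c1ccc(F)cc1Cl)Cc1ccc(Nc2ncnc3cc(Cl)ccc23)cc1`) gives > 100000 nM as a limit of the assay and not as a number. Compound 2 (`O=S(=O)(/C=C/c1ccc(C(F)(F)F)cc1F)Cc1ccc(Nc2ncnc3cc(Cl)ccc23)cc1`) gives > 100000 nM as a limit as well. Compound 1 (`O=S(=O)(/C=C/c1ccc(F)cc1F)Cc1ccc(Nc2ncnc3ccccc23)cc1`), which carries the 2,4-difluorophenyl group, gives > 100000 nM as a limit as well. Compound 3 therefore offers no number to start from.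

The change is fluoro in place of chloro (fluoro in place of chloro on an aromatic carbon) on an aromatic carbon of a six-membered aromatic ring of carbon only, ortho to a large group and meta to a fluoro group, so that 2-chloro-4-fluorophenyl becomes 2,4-difluorophenyl. Among the compounds with values here, the one measured step at this place (a step that the two limits leave unreadable from compound 2 to compound 3) has no readable size and sets no scale for the new step.

Because of the limit of > 100000 nM in this assay, at which 3 of the 3 values shown sit, for compound 3 as for compound 1 and compound 2, no shift beyond the scatter is expected in this assay in either direction. The expected step (a number no higher from compound 3 to compound 4 (the limit leaves the size open)) is accordingly no change beyond the scatter. Compound 4 is estimated at 100000 nM with a range of 30000 nM to 200000 nM and is expected most likely to read as a limit again.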

Compound 4, concentration for 50% growth inhibition: > 100000 nM
Compound 4: a limit, no number; the forecaster's own chance of this, stated with the estimate: 85%; the middle value lies on the limit itself.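

Compound 4 gives > 100000 nM in this assay, a limit of the assay and not a number. The steps to compound 4 from compound 1, compound 2 and compound 3 therefore cannot be read: the limit of > 100000 nM in this assay, at which 4 of the 4 values shown sit.

The compounds shown leave open how far any of these four lies beyond the limit, and whether any change to them would give a readable number in this assay.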